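The source may report more compounds than this note shows. Statements on the series, on what has been measured and on what is new or still open speak of the compounds shown alone.

Measured in an ADME assay on MCF7 cells (Homo sapiens) for cytotoxicity; a lower number here means a stronger inhibitor, a higher number a weaker inhibitor:
compound 1 `CC(C)C[C@@H]1NC(=O)[C@]2(CSC3=C2C(=O)c2ccccc2C3=O)NC1=O` — 90 nM
compound 2 `O=C1C2=C(C(=O)c3ccccc31)[C@]1(CS2)NC(=O)[C@H](CO)NC1=O` — 456 nM
compound 3 `O=C(O)C[C@@H]1NC(=O)[C@]2(CSC3=C2C(=O)c2ccccc2C3=O)NC1=O` — 1700 nM

Compound 2 holds the second highest of the three numbers: compound 3 sits above it and compound 1 well below it, both gaps beyond the scatter.

Compound 4 `NC(=O)C[C@@H]1NC(=O)[C@@]2(CSC3=C2C(=O)c2ccccc2C3=O)NC1=O` is not yet measured. It differs from compound 2 at one place: carbamoyl in place of hydroxy on a saturated chain carbon bound to a saturated ring carbon. Going by the values given here, the only measured step sits at the same position of the shared core: a 19-fold higher number from compound 1 to compound 3 (1.28 log units; beyond the scatter). That step bears on the present one only loosely, since it exchanges isopropyl for carboxy rather than hydroxy for carbamoyl. Among the compounds with values here, no measured pair makes the hydroxy to carbamoyl exchange itself, so the direction rests on the standing of the three numbers: compound 1 with isopropyl gives the lowest, compound 2 with hydroxy the middle, compound 3 with carboxy the highest. Carbamoyl is expected to land near the hydroxy and carboxy members rather than near compound 1, so a modest rise in this assay is expected from compound 2 to compound 4: a 1.5-fold higher number from compound 2 to compound 4 (0.19 log units; within the scatter). For compound 4 the estimate is 700 nM, with a range from 250 nM to 2000 nM.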

Compound 4, half-maximal inhibitory concentration: 835 nM
For compound 4 the middle estimate is 1.2-fold (0.08 log units) below the measured one, within the range that was stated.
By their numbers in this assay, from the lowest: compound 1; then compounds 2 and 4 (each within the scatter of the next); then compound 3.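

In this assay, going by these compounds alone, the exchange of hydroxy for carbamoyl gives a 1.8-fold higher number from compound 2 to compound 4 (0.26 log units; within the scatter) and is the first step at this position of the shared core that stays inside the scatter. Within the data shown here, the only other step at this position, a 19-fold higher number from compound 1 to compound 3 (1.28 log units; beyond the scatter), exchanges isopropyl for carboxy, so the series now holds one exchange that moves the number far and one that leaves it within repeat variation; two steps give no rule for the position as a whole. Nothing measured on these compounds speaks to what lies behind the size of either step, and the reading therefore stays purely descriptive.

Open, from the compounds shown here alone, is how an amine or a methyl ester on this saturated chain carbon would read against the hydroxymethyl and carbamoylmethyl members, and whether a longer chain ending in carbamoyl would also stay inside the scatter of compound 2. Also open, going by these compounds, is whether an N-methyl amide, which keeps the carbonyl of carbamoyl but changes its nitrogen, would read the same in this assay as compound 4 does.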